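Ethyl in place of hydrogen on the tetrazole core

A few compounds are considered here, and "the series" means these few. Any claim that something is new, unique, unknown or untested is made for them only; others in the source may bear on it.

In a functional assay on the whole organism (strain Sprague-Dawley) for inhibition, with Rattus norvegicus as the target (on this read-out higher numbers stand for an effect only at larger amounts of compound and lower numbers for an effect already at smaller amounts), compound 3 `c1ccc2ncc(-c3nn[nH]n3)cc2c1` gives 25 mg/kg, level with compound 1 `FC(F)(F)c1ccc2cc(-c3nn[nH]n3)cnc2c1` at 25 mg/kg, and together these are the lowest of the three numbers; compound 2 `CCc1cccc2cc(C(=O)O)cnc12` gives 75 mg/kg, a clearly larger amount. Compound 4 `CCc1cccc2cc(-c3nn[nH]n3)cnc12` differs from compound 3 as follows: ethyl in place of hydrogen on an aromatic carbon. Within the data shown here, the only measured step on the shared core, no change at the digits printed from compound 1 to compound 3 (within the scatter), left the read-out within the scatter. Compound 2 carries the ethyl group but differs from compound 3 in a second place as well, so its value bears only loosely on this step. Among the measured compounds shown here, no step of exactly this kind has been measured, so no shift beyond the scatter is expected. The expected step is a 1.2-fold higher number from compound 3 to compound 4 (0.08 log units; within the scatter). Compound 4 is estimated at 30 mg/kg, within 12 mg/kg to 75 mg/kg.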

Compound 4, minimum effective dose: 5 mg/kg
For compound 4 the middle estimate is 6.0-fold (0.78 log units) above the measured one, outside the stated range (below it).
By their numbers in this assay, from the lowest: compound 4; then compounds 1 and 3 (each within the scatter of the next); then compound 2.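

Ethyl on this aromatic carbon, ortho to a fused ring, gives a step beyond the scatter in this assay: a 5.0-fold lower number from compound 3 to compound 4 (0.70 log units; beyond the scatter). Among these compounds, with ethyl held in place, 2H-tetrazol-5-yl in place of carboxy gives a 15-fold lower number from compound 2 to compound 4 (1.18 log units; beyond the scatter), the first measured comparison of these two groups on the shared core. Nothing at hand accounts for either step.

Open, as far as these compounds go, is whether methyl or a longer chain such as propyl on this carbon would match ethyl. Also open, from the compounds shown here alone, is whether an amine there would keep the effect at such small amounts.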